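Swapping a nitro for a methoxy on a small aryl triazene

The compounds below may be only part of what the source reports. "The series", "measured", "known", "first", "only" and "open" are said of these compounds alone.

Of the compounds shown here, two have been tested in an ADME assay on MDBK cells (Bos taurus) for cytotoxicity, read by MTT assay, with a stated time of 96 h; on this read-out higher numbers stand for lower toxicity in this test and lower numbers for higher toxicity in this test. Compound 1, `Cc1c(/N=N/c2cccc(C(F)(F)F)c2)ccc(NC[C@@H]2CCCN3CCCC[C@H]23)c1C`, carries a trifluoromethyl-bearing azo unit and a bulky bicyclic amine; in this assay compound 1 gives 52000 nM. Compound 2, `O=[N+]([O-])c1ccc(/N=N/N2CCCC2)cc1`, is far smaller, an aryl triazene with a nitro group on the ring. For compound 2 this assay reports only a limit, > 100000 nM, not a number. That places compound 2 at the upper edge of the values recorded, as noted in the limit of > 100000 nM in this assay, at which 1 of the 2 values shown sits: the less toxic end of what the test can resolve.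

The next compound, compound 3, `COc1ccc(/N=N/N2CCCC2)cc1`, keeps the whole triazene framework of compound 2 and changes one group: methoxy in place of nitro on an aromatic carbon. Among the compounds with values here, no measured pair that differs in just one place is available here, so the effect of this change in this assay has to be an expectation rather than a reading. The step of a number no higher from compound 2 to compound 3 (the limit leaves the size open) is expected to stay within the usual scatter, with no direction clearly favoured. Compound 3 is therefore estimated at 100000 nM, within a range of 40000 nM to 300000 nM, and it may well come back as a limit again.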

Compound 3, half-maximal cytotoxic concentration: 60000 nM
Beside the measured number, compound 3's estimate is 1.7-fold (0.22 log units) above it; the measured number falls inside the stated range.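

With methoxy on this aromatic carbon, para to a group of 7 heavy atoms, the small triazene framework now gives a true number in this assay instead of a limit, so a change at this position can bring a reading inside the range the test resolves. Putting methoxy in place of nitro gives an at least 1.6-fold lower number from compound 2 to compound 3 (0.22 log units; that floor lies within the scatter), which means the change can be read only as a minimum and not as a measured size. Going by these compounds, the real size of the step stays unknown, because compound 2 is held only by a limit: the limit of > 100000 nM in this assay, at which 1 of the 3 values shown sits.

Only nitro and methoxy are shown at this position, so a single pair cannot tell how the read-out would respond to another group there, such as an amine or a carboxylic acid. On these data alone, compound 1 differs from compound 2 and compound 3 in more than one place, so it adds nothing on this change, and whether the same swap would act alike on another framework also remains open.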